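This account rests on a few compounds, and the source may have more. Where it says the series, first, only, none or still open, it means among the compounds named here.

Series notes. Three ureas built on one shared core carry numbers in a functional assay on MX1 cells (Homo sapiens) for inhibition, read by MTT assay, with a stated time of 120 h; on this read-out lower numbers stand for stronger inhibition and higher numbers for weaker inhibition. Compound 1 `CC(NC(=O)c1cccc(-c2ccc(NC(=O)Nc3ccc(Cl)c(C(F)(F)F)c3)cc2)c1)c1ccccc1` gives 5240 nM in this assay. Compound 2 `CC(NC(=O)c1ccc(-c2ccc(NC(=O)Nc3ccc(Cl)c(C(F)(F)F)c3)cc2)cc1)c1ccccc1` gives 4630 nM in this assay; the gap between compound 1 and compound 2 lies within the scatter, so nothing separates the two. Compound 3 `CC1CN(C(=O)/C=C/c2ccc(NC(=O)Nc3ccc(Cl)c(C(F)(F)F)c3)cc2)CC(C)O1` gives 12800 nM in this assay, and its gap to compound 1 lies beyond the scatter. Compound 1 thus holds the second highest of the three numbers, indistinguishable from compound 2 and clearly below compound 3.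

Compound 4 `CNC(=O)c1cccc(-c2ccc(NC(=O)Nc3ccc(Cl)c(C(F)(F)F)c3)cc2)c1` differs from compound 1 in one place: methyl in place of 1-phenylethyl on an amide-type nitrogen. Among the compounds with values here, no measured pair in the set tests this change, so its size is open and rests on the structural change alone. The expectation is a step of a 1.7-fold higher number from compound 1 to compound 4 (0.23 log units; within the scatter), upward toward weaker inhibition, of a size that may just reach beyond the scatter. Compound 4 is accordingly estimated at 9000 nM in this assay, with an expected range from 3500 nM to 25000 nM.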

Compound 4, half-maximal inhibitory concentration: > 50000 nM
Compound 4 ended at the assay's limit (the forecaster's own chance of this, stated with the estimate: 10%); middle value at least 5.5-fold (0.74 log units) away from the limit.
By their numbers in this assay, from the lowest: compounds 2 and 1 (each within the scatter of the next); then compound 3. At a limit, above all of these: compound 4.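

In this assay, within the data shown here, the amide-type nitrogen proves to be a position that responds to substitution, with methyl in place of 1-phenylethyl giving an at least 9.5-fold higher number from compound 1 to compound 4 (0.97 log units; beyond the scatter), a change beyond the scatter that no earlier pair could show. Compound 4 sits at a limit of the assay, > 50000 nM, and this is not a measured number. The step therefore gives only a lower bound on the effect of losing 1-phenylethyl, since its full size cannot be read: the limit of > 50000 nM in this assay, at which 1 of the 4 values shown sits.

A single pair cannot show whether the aromatic ring or the branched carbon of 1-phenylethyl accounts for the difference; benzyl, cyclohexyl or ethyl on the same nitrogen would separate these. From the compounds shown here alone, it also remains open whether the same change would have a comparable effect on the core of compound 2.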